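A few compounds are considered here, and "the series" means these few. Any claim that something is new, unique, unknown or untested is made for them only; others in the source may bear on it.

Two compounds that share one core are a useful starting pair. Compound 1 `CSc1c(F)cccc1NCC1=NCCN1` and compound 2 `CS(=O)(=O)c1c(F)cccc1NCC1=NCCN1` differ only in one group. In a functional assay on CHO cells for agonist activity at Alpha-2C adrenergic receptor (Homo sapiens) (on this read-out higher numbers stand for larger maximal responses and lower numbers for smaller maximal responses), compound 1 gives 104%, while compound 2 gives 93%. The change between them is methylsulfonyl in place of methylsulfanyl on an aromatic carbon, and it produced a number 11 percentage points lower from compound 1 to compound 2 (beyond the scatter).

Compound 3 `CSc1ccc(C(F)(F)F)cc1NCC1=NCCN1` carries a different core; how its core differs from that of compound 1 is not broken down here. In this assay compound 3 gives 45%, the lowest of the three numbers, with compound 2 the nearest and compound 1 the furthest.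

Compound 4 `CS(=O)(=O)c1ccc(C(F)(F)F)cc1NCC1=NCCN1` has not yet been tested. It is made from compound 3 by methylsulfonyl in place of methylsulfanyl on an aromatic carbon. Going by the values given here, this is the same kind of change as the one from compound 1 to compound 2, though not the same: in the first pair the place is ortho to a fluoro group and ortho to a group of 7 heavy atoms, whereas here it is ortho to a group of 7 heavy atoms and para to a trifluoromethyl group.

A step of about a number 9 percentage points lower from compound 3 to compound 4 (within the scatter) is therefore expected, resting on the measured pair, where the change gave a number 11 percentage points lower from compound 1 to compound 2 (beyond the scatter), and on compound 3 starting from a low number. Compound 4 is accordingly estimated at 36% in this assay, expected to fall between 20% and 55%.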

Compound 4, largest response reached (reported as maximum), in percent of the reference or control that the assay uses: 25%
Compound 4: middle estimate off by 11 percentage points, on the high side; the measured number falls inside the stated range.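

In this assay, putting methylsulfonyl in place of methylsulfanyl on the core of compound 3 gave a number 20 percentage points lower from compound 3 to compound 4 (beyond the scatter), so the change lowers the maximal response here as it did on the core of compound 1. Set side by side, the two steps agree in direction and cannot be told apart in size: the same change on two cores in this assay, a number 11 percentage points lower (beyond the scatter) from compound 1 to compound 2 and a number 20 percentage points lower (beyond the scatter) from compound 3 to compound 4, 9 percentage points apart, within the scatter of two such steps. This shows that the change carried over between these two cores, but two pairs are too few to show that it would do so on any other core in the series, and the numbers alone do not say what causes the drop.

The compounds shown leave open how a methylsulfinyl group, a nitrile or an amine would read at the same place on the ring, which would show whether the drop is particular to methylsulfonyl. On these data alone, it also remains open whether the same step would appear on a core carrying a chloro group or a methoxy group in place of the fluoro or trifluoromethyl groups seen here.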